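The source may hold more compounds than are shown below. What is called first, only, known or untested is meant among the compounds shown, and "the series" means these compounds.

Measured so far in a functional assay on HL-60 cells (Homo sapiens) for inhibition, read by MTT assay, with a stated time of 72 h; a lower number here means a stronger inhibitor, a higher number a weaker inhibitor:
- compound 1, `C=C(C)c1cccc(N2CCN(C(=O)c3oc(C)nc3-c3ccccc3F)CC2)c1`: "not active" (no number reported)
- compound 2, `Cc1nc(-c2cccc(F)c2)c(C(=O)N2CCN(c3cc(Cl)cc(Cl)c3)CC2)o1`: 41.7 nM
- compound 3, `Cc1nc(-c2cccc(OP(=O)(O)O)c2)c(C(=O)N2CCN(c3cccc(Cl)c3)CC2)o1`: > 1000 nM

Compound 1 has no number in this assay; it is reported only as not active, so it cannot be placed against the others on the scale. Among the compounds with values here, compound 3 also gives no number: its result of > 1000 nM is a limit of the assay, and it is the one value among the three that sits at the limit of > 1000 nM in this assay, at which 1 of the 3 values shown sits. Compound 2 is the only one of the three with a measured concentration, 41.7 nM.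

Not yet measured is compound 4, `Cc1nc(-c2ccccc2F)c(C(=O)N2CCN(c3cc(F)cc(F)c3)CC2)o1`. Against compound 1 it differs in one place: 3,5-difluorophenyl in place of 3-(1-methylethenyl)phenyl on an amine nitrogen in a ring. Within the data shown here, no step between two measured compounds covers this change, so its size cannot be read from the data. Given that compound 1 is not active and that compound 2, which carries a dihalogenated phenyl on the same ring nitrogen, gives 41.7 nM, the expectation is a move toward stronger inhibition in this assay, of uncertain size. Compound 4 is estimated at 150 nM, within a range of 25 nM to 900 nM.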

Compound 4, half-maximal inhibitory concentration: 186 nM
Beside the measured number, compound 4's estimate is 1.2-fold (0.09 log units) below it; the range from low to high includes it.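

In this assay compound 4 gives 186 nM, but compound 1 has no number, so no new step can be read between compound 1 and compound 4. Nothing measured here accounts for the value of compound 4. The compounds shown leave open how large the effect of exchanging 3-(1-methylethenyl)phenyl for 3,5-difluorophenyl is.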